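A few compounds are considered here, and "the series" means these few. Any claim that something is new, unique, unknown or untested is made for them only; others in the source may bear on it.

The measured compounds:

compound 1, `O=C(/C=C/c1cccc2ccccc12)c1cccc(NC(=O)c2cc(-c3ccncc3)n[nH]2)c1`, 64500 nM
compound 2, `O=C(/C=C/c1cccs1)c1cccc(NC(=O)c2cc(-c3ccncc3)n[nH]2)c1`, 27600 nM
compound 3, `O=C(/C=C/c1ccccc1Cl)c1cccc(NC(=O)c2cc(-c3ccncc3)n[nH]2)c1`, 27700 nM

Three compounds share the core of compound 1 and differ only in the group on a double-bonded chain carbon bound to a double-bonded chain carbon. In a functional assay, read by spectrophotometry, tested at 100 uM (on this read-out higher numbers stand for weaker inhibition and lower numbers for stronger inhibition), compound 1 gives 64500 nM, the highest of the three numbers; compound 2 gives 27600 nM and compound 3 gives 27700 nM, so both stand beyond the scatter from compound 1, and their own two values lie within the scatter of each other.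

Compound 4, `O=C(/C=C/c1ccc([N+](=O)[O-])cc1)c1cccc(NC(=O)c2cc(-c3ccncc3)n[nH]2)c1`, has not yet been measured in this assay. It departs from compound 1 by 4-nitrophenyl in place of naphthalen-1-yl on a double-bonded chain carbon bound to a double-bonded chain carbon. Going by the values given here, two measured steps bear on this: the naphthalen-1-yl group was already exchanged for a single ring twice, giving a 2.3-fold lower number from compound 1 to compound 2 (0.37 log units; beyond the scatter) and a 2.3-fold lower number from compound 1 to compound 3 (0.37 log units; beyond the scatter), the same size in the same direction each time. Among the compounds with values here, compound 4 also carries a single six-membered ring in place of naphthalen-1-yl, so a step of comparable size toward a lower number is expected in this assay, a 2.3-fold lower number from compound 1 to compound 4 (0.36 log units; beyond the scatter), although no measured step shows what a 4-nitrophenyl group itself does here. Compound 4 is therefore expected to give about 28000 nM, between 12000 nM and 65000 nM.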

Compound 4, half-maximal inhibitory concentration: 52800 nM
Beside the measured number, compound 4's estimate is 1.9-fold (0.28 log units) below it; the measured number falls inside the stated range.
By their numbers in this assay, from the lowest: compounds 2, 3, 4 and 1 (each within the scatter of the next, the first and the last beyond it).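

In this assay, exchanging naphthalen-1-yl for a single ring at this position does not always give a step beyond the scatter: 4-nitrophenyl gives only a small one (a 1.2-fold lower number from compound 1 to compound 4 (0.09 log units; within the scatter)), so having one ring in place of two does not by itself account for the values of compounds 2 and 3. The 4-nitrophenyl group cannot be separated from the other single rings either (a 1.9-fold higher number from compound 3 to compound 4 (0.28 log units; within the scatter); a 1.9-fold higher number from compound 2 to compound 4 (0.28 log units; within the scatter)), which leaves compound 4 unassigned to either side, and the only separation at this position remains that of compound 1 from compounds 2 and 3. Nothing available here explains this outcome.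

The compounds shown leave open where a plain phenyl group, carrying no substituent, would fall in this assay, so the part played by the ring cannot be told apart from the part played by the nitro group. They also leave open how a 4-aminophenyl group, a 4-carboxyphenyl group or a saturated cyclohexyl ring would read on a double-bonded chain carbon bound to a double-bonded chain carbon.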